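This account rests on a few compounds, and the source may have more. Where it says the series, first, only, none or still open, it means among the compounds named here.

Working notes on an ADME assay for permeability, using PAMPA, at pH 7.4; a lower number here means that the compound crosses the layer more slowly, a higher number that the compound crosses the layer faster: compound 1 `CSc1ccc(NC(=O)Nc2cc(C)nc3ccccc23)cc1` gives 473 10^-6 cm/s and compound 2 `COC(=O)c1ccc(NC(=O)Nc2cc(C)nc3ccccc23)cc1` gives 448 10^-6 cm/s, so compound 2 stands level with compound 1 within the scatter. Compound 3 `Cc1cc(NC(=O)Nc2ccc(SC(F)(F)F)cc2)c2ccccc2n1` carries (trifluoromethyl)sulfanyl in place of methoxycarbonyl on an aromatic carbon. Among the measured compounds shown here, the only measured step that bears on this change is a 1.1-fold lower number from compound 1 to compound 2 (0.02 log units; within the scatter), a swap of methylsulfanyl for methoxycarbonyl on an aromatic carbon. That single step is thin evidence, but no movement beyond the scatter is expected in this assay. The expected step is a 1.0-fold higher number from compound 2 to compound 3 (0.00 log units; within the scatter). For compound 3 the estimate is 450 10^-6 cm/s, with an expected range of 230 10^-6 cm/s to 750 10^-6 cm/s.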

Compound 3, apparent permeability: 206 10^-6 cm/s
Compound 3: the middle estimate sits 2.2-fold (0.34 log units) above what was measured, outside the stated range (below it).
By their numbers in this assay, from the lowest: compound 3; then compounds 2 and 1 (each within the scatter of the next).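

In this assay, the position on the six-membered aromatic ring of carbon only, para to a large group, turns out not to be indifferent to its substituent, although compound 1 and compound 2 stood level: (trifluoromethyl)sulfanyl in place of methoxycarbonyl gives a 2.2-fold lower number from compound 2 to compound 3 (0.34 log units; beyond the scatter) in this series. The sulfur-bearing pair shows the same direction, with trifluoromethyl in place of methyl on the sulfur giving a 2.3-fold lower number from compound 1 to compound 3 (0.36 log units; beyond the scatter) at that atom. No measurement at hand accounts for this drop. Still open, from the compounds shown here alone, is whether a trifluoromethyl directly on the ring, an amine or a carboxylic acid at this position would also lower the number. Going by these compounds, whether these steps carry over to another core also remains open.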